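This account rests on a few compounds, and the source may have more. Where it says the series, first, only, none or still open, it means among the compounds named here.

In an ADME assay on microsomes from liver (Mus musculus) for metabolic stability (on this read-out lower numbers stand for slow clearance and higher numbers for fast clearance), the compounds measured so far give limits only:
- Compound 1 `O=C(O)Cn1nc(Cc2nc3cc(Cl)c(OC(F)(F)F)cc3[nH]2)c2ccccc2c1=O` gives < 81.7 mL/min/kg as a limit
- Compound 2 `O=C(O)Cn1nc(Cc2cn3cc(OCC4CC4)c(Cl)cc3n2)c2ccccc2c1=O` gives < 58.4 mL/min/kg as a limit
- Compound 3 `O=C(O)C1(c2nn(Cc3cn4cc(OCC5CC5)c(Cl)cc4n3)c3ccccc3c2=O)CC1` gives < 53.4 mL/min/kg as a limit

Compound 1 stands at the limit of < 81.7 mL/min/kg in this assay, at which 1 of the 3 values shown sits, and has no number of its own. Compound 4 `O=C(O)Cn1nc(Cc2nc3cc(Cl)c(OCC4CC4)cc3[nH]2)c2ccccc2c1=O` has cyclopropylmethyl in place of trifluoromethyl on an oxygen on an aromatic ring. Compound 2 also carries cyclopropylmethoxy and gives only a limit (< 58.4 mL/min/kg). Compound 3 carries it too and likewise gives only a limit (< 53.4 mL/min/kg). Among the compounds with values here, no measured pair isolates this change, so no step beyond the scatter is expected in this assay, and the estimated step is a step that the limit leaves unreadable from compound 1 to compound 4 in size. For compound 4 the estimate is 45 mL/min/kg, with an expected range of 20 mL/min/kg to 80 mL/min/kg.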

Compound 4, clearance: 147 mL/min/kg
Compound 4: the middle estimate sits 3.3-fold (0.51 log units) below what was measured; measured number outside the range, above it.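

In this assay compound 4 gives the only actual number among the compounds shown, and it carries cyclopropylmethoxy. On an oxygen on an aromatic ring, cyclopropylmethyl in place of trifluoromethyl gives an at least 1.7-fold higher number from compound 1 to compound 4 (0.25 log units; that floor lies within the scatter). The full size of this step cannot be read because compound 1 has only a limit: the limit of < 81.7 mL/min/kg in this assay, at which 1 of the 4 values shown sits.

No other step can be read among the compounds shown. Open, going by these compounds, is how a different group on this oxygen, such as methyl or a longer chain, would read in this assay.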